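A hydroxy swap at the edge of the assay

The source may report more compounds than this note shows. Statements on the series, on what has been measured and on what is new or still open speak of the compounds shown alone.

Of the compounds shown here, two have been tested so far in a functional assay on Vero cells (Chlorocebus sabaeus) for inhibition (on this read-out lower numbers stand for stronger inhibition and higher numbers for weaker inhibition), and neither gave a true number. Compound 1 `OC[C@H]1O[C@H](n2cnc3c(O)ncnc32)CS1` reached only a limit, > 100000 nM. Compound 2 `CNc1ncnc2c1ncn2[C@H]1CS[C@@H](CO)O1` also reached only a limit, > 100000 nM. The whole picture so far is the limit of > 100000 nM in this assay, at which 2 of the 2 values shown sit.

Compound 3 `OC[C@H]1O[C@@H](n2cnc3c(O)ncnc32)CS1` has yet to be measured. Moving to it from compound 2 puts hydroxy in place of methylamino on an aromatic carbon. Within the data shown here, no measured pair of compounds shows what this swap does, so the expectation has little to rest on. It starts from compound 2, whose limit is > 100000 nM. The expected change in this assay is a number no higher from compound 2 to compound 3 (the limit leaves the size open), with nothing beyond the usual scatter. For compound 3 the estimated value is 100000 nM, with an expected range from 40000 nM to 250000 nM.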

Compound 3, half-maximal inhibitory concentration: > 100000 nM
Compound 3: only a limit was reported (the forecaster's own chance of this, stated with the estimate: 85%); the middle value lies on the limit itself.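

Compound 3 also gives only a limit, so the steps to it from compound 1 and from compound 2 cannot be read in this assay: the limit of > 100000 nM in this assay, at which 3 of the 3 values shown sit. The compounds shown leave open whether hydroxy, methylamino or either drawn configuration makes any difference to inhibition.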